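The source may report more compounds than this note shows. Statements on the series, on what has been measured and on what is new or still open speak of the compounds shown alone.

Measured compounds:
compound 1, `CC(C)(C)OC(=O)NCCC[C@@H]1N=C2C[C@@H]3C[C@@H](C3(C)C)[C@]2(C)OC1=O`: 6600 nM
compound 2, `CC1(C)[C@H]2CC[C@]1(C)[C@H]1OC(=O)CN=C21`: 145000 nM

In a functional assay on PC-3 cells (Homo sapiens) for antiproliferative activity, read by sulforhodamine B assay, with a stated time of 48 h (on this read-out lower numbers stand for stronger inhibition and higher numbers for weaker inhibition), compound 1 gives 6600 nM, the lowest of the two numbers in hand. Compound 2, which gives 145000 nM in this assay, sits a long way higher, well beyond the scatter, so compound 1 is the stronger of the two.

Compound 3, `CC(C)(C)OC(=O)NCCC[C@H]1N=C2C[C@H]3C[C@H](C3(C)C)[C@@]2(C)OC1=O`, has not yet been measured. It differs from compound 1 by the two compounds have the same atoms and bonds and differ only in configuration as drawn: 4 of 4 stereo elements differ (all stereocentres are inverted: mirror images); a stereocentre at a saturated ring carbon is drawn S in compound 1 and R in compound 3; a stereocentre at a saturated ring carbon is drawn S in compound 1 and R in compound 3; a stereocentre at a saturated ring carbon is drawn S in compound 1 and R in compound 3; a stereocentre at a saturated ring carbon is drawn S in compound 1 and R in compound 3. Every stereocentre is drawn the opposite way, so compound 3 is the mirror image of compound 1 with nothing added or removed.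

For the measured compounds named here, no measured pair in this set shows what mirror images do in this assay, so the direction of the step cannot be read from the data. Mirror images often give clearly different numbers, and a loss is estimated here. Compound 3 is expected to give 15000 nM, in the range 4000 nM to 70000 nM, which amounts to an expected step of a 2.3-fold higher number from compound 1 to compound 3 (0.36 log units; beyond the scatter).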

Compound 3, half-maximal inhibitory concentration: 60000 nM
Compound 3: the middle estimate sits 4.0-fold (0.60 log units) below what was measured; measured number inside the range.
By their numbers in this assay, from the lowest: compound 1; then compound 3; then compound 2.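

Inverting every stereocentre gives a 9.1-fold higher number from compound 1 to compound 3 (0.96 log units; beyond the scatter) in this assay, so this read-out separates the two mirror images. The earlier compounds shown here could not show this: compound 2 differs from compound 1 in more than configuration, and no pair of mirror images was yet in hand. The gap can be put down to the three-dimensional arrangement alone, because nothing else changes: the fact that compounds 1 and 3 differ only in the configuration as drawn.

Which of the four stereocentres matters most remains open: no compound here inverts only some of them. It is also unknown how the side chain contributes to the activity of compound 1, and a free amine or a carboxylic acid in place of the carbamate would be needed to test that.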